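Pyridazin-3-yl in place of pyrimidin-4-yl on a short-lived compound

This account rests on a few compounds, and the source may have more. Where it says the series, first, only, none or still open, it means among the compounds named here.

In an ADME assay on cells (Hepatocyte, Rattus norvegicus) for metabolic stability (on this read-out higher numbers stand for a longer-lived compound and lower numbers for a shorter-lived compound), compound 1 `O=C(C1CCN(c2ccncn2)CC1)N1N=CC[C@H]1c1ccccc1` gives < 0.4 h, which is a limit of the assay and not a number. Compound 1 therefore sits at the limit of < 0.4 h in this assay, at which 1 of the 2 values shown sits. Going by the values given here, compound 2 `N#Cc1nccc(N2CCC(C(=O)N3N=CC[C@H]3c3cc(F)cc(F)c3)CC2)n1` gives a measured 0.917 h in this assay, but no single-place step connects it to compound 1.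

Compound 3 `O=C(C1CCN(c2cccnn2)CC1)N1N=CC[C@H]1c1ccccc1` has the same atoms as compound 1, joined differently: pyridazin-3-yl in place of pyrimidin-4-yl on an amine nitrogen in a ring, (pyridazin-3-yl in place of pyrimidin-4-yl on an amine nitrogen in a ring). Among the compounds with values here, no measured step shows what such a change does. No step beyond the scatter is expected in this assay, in either direction. The expected step is a step that the limit leaves unreadable from compound 1 to compound 3, and this is an estimate. Compound 3 is expected at 0.3 h, with an estimated range of 0.15 h to 0.6 h.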

Compound 3, half-life: < 0.517 h
Compound 3: a limit, no number; the forecaster's own chance of this, stated with the estimate: 65%; the middle value is on the limit's open side.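

In this assay compound 1 and compound 3 each give a limit and not a number, so no step can be read between them. The compounds shown leave open what pyridazin-3-yl in place of pyrimidin-4-yl does to the half-life on this core.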